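The source may hold more compounds than are shown below. What is called first, only, known or untested is meant among the compounds shown, and "the series" means these compounds.

Compound 3 `O=[N+]([O-])c1ccc(C2=NOC(c3ccc(N4CCN(Cc5cccnc5)CC4)cc3)C2)o1` carries a (pyridin-3-yl)methyl group on the ring nitrogen of its piperazine-like ring. In an ADME assay on HeLa cells (Homo sapiens) for cytotoxicity, read by MTT assay, with a stated time of 96 h (on this read-out lower numbers stand for stronger inhibition and higher numbers for weaker inhibition), compound 3 gives only a limit, > 50000 nM. Its two close relatives were read in the same way. Compound 1 `COc1ccc(CN2CCN(c3ccc(C4CC(c5ccc([N+](=O)[O-])o5)=NO4)cc3)CC2)cn1` gives only a limit in this assay, > 50000 nM. Compound 2 `O=[N+]([O-])c1ccc(C2=NOC(c3ccc(N4CCN(Cc5ccc(F)nc5)CC4)cc3)C2)o1` also gives only a limit, > 50000 nM. Since every value sits at the edge of what the assay can report, the step from compound 1 to compound 2 a step that the two limits leave unreadable from compound 1 to compound 2, the step from compound 1 to compound 3 a step that the two limits leave unreadable from compound 1 to compound 3 and the step from compound 2 to compound 3 a step that the two limits leave unreadable from compound 2 to compound 3 cannot be sized, because of the limit of > 50000 nM in this assay, at which 3 of the 3 values shown sit.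

Compound 4 `CC(C)(C)OC(=O)N1CCN(c2ccc(C3CC(c4ccc([N+](=O)[O-])o4)=NO3)cc2)CC1` differs from compound 3 in one place: tert-butoxycarbonyl in place of (pyridin-3-yl)methyl on an amine nitrogen in a ring. Among the compounds with values here, none of the measured steps touches this position, and none yields a readable size, so they give no direction to expect. What the three results do show is that every compound examined so far fails to reach a measurable value in this assay. On that basis the change is expected to leave compound 4 at or near the same limit, and compound 4 is estimated at 60000 nM, with a range from 20000 nM to 200000 nM. The step expected from this estimate is a step that the limit leaves unreadable from compound 3 to compound 4, with compound 4 most likely reported only as a limit.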

Compound 4, half-maximal inhibitory concentration: > 50000 nM
Compound 4: only a limit was reported; the forecaster's own chance of this, stated with the estimate: 75%; the middle value is on the limit's open side.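

Compound 4 joins compound 1, compound 2 and compound 3 at the edge of what this assay can report, and no step among these four compounds can be read, because each result is a limit and not a number: (the limit of > 50000 nM in this assay, at which 4 of the 4 values shown sit). The compounds shown leave open whether the group on the amine nitrogen of the ring changes the result in this assay at all.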